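Chloro for cyano on the pyridinone core of compound 1

The source may hold more compounds than are shown below. What is called first, only, known or untested is meant among the compounds shown, and "the series" means these compounds.

Compound 1, with the structure `N#Cc1c(N2CCC(c3ccccc3)CC2)ccn(CC2CC2)c1=O`, is examined in a functional assay on CHO cells for positive allosteric modulation of metabotropic glutamate receptor 2 (Homo sapiens), with a stated time of 30 min (a lower number here means a smaller maximal response, a higher number a larger maximal response), where compound 1 gives 309%. Among the two compounds with a number, compound 1 stands highest; its nearest neighbour is compound 2, whose structure is `COc1ccc(C2CCN(c3ccn(CC4CC4)c(=O)c3C#N)CC2)cc1` and which in this assay gives 257%. The step of a number 52 percentage points lower from compound 1 to compound 2 (beyond the scatter) is beyond the scatter and concerns a methoxy in place of hydrogen on the phenyl ring, far from the cyano group.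

Compound 3, with the structure `O=c1c(Cl)c(N2CCC(c3ccccc3)CC2)ccn1CC1CC1`, has not yet been measured. Its difference from compound 1 is chloro in place of cyano on an aromatic carbon. Among the compounds with values here, no measured step changes this position, so nothing among the two compounds speaks directly to this exchange; the only known step, from compound 1 to compound 2, alters a distant part of the molecule. Without direct guidance, the estimate for compound 3 is set somewhat below compound 1, with a wide range. Compound 3 is expected to give about 240%, between 150% and 330%, which corresponds to an estimated step of a number 69 percentage points lower from compound 1 to compound 3 (beyond the scatter).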

Compound 3, largest response reached (Emax), in percent of the reference or control that the assay uses: 259%
The estimate for compound 3 lay 19 percentage points below the measured number; measured number inside the range.
By their numbers in this assay, from the lowest: compounds 2 and 3 (each within the scatter of the next); then compound 1.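

In this assay, the exchange of cyano for chloro on this aromatic carbon gives a number 50 percentage points lower from compound 1 to compound 3 (beyond the scatter), so the position responds to the change, yet without the nitrile compound 3 still reaches 259%. Within the data shown here, the earlier step altered only the phenyl ring, whereas this one gives the first reading at the position two atoms from the ring nitrogen, where a group with a triple bond and a hydrogen-bond acceptor leaves and a single chlorine atom with no acceptor enters. No independent measurement accompanies these compounds that could account for the size of this step.

The compounds shown leave open how a methyl group, a bromine atom or an amine at this position would compare with cyano and chloro in this assay. Among these compounds, they also leave open whether the same exchange would give a step of similar size with the methoxy of compound 2 in place, since only two groups have been read here and only on the unsubstituted phenyl ring of compound 1.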